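Series notes: a second chloro added to compound 2

A few compounds are considered here, and "the series" means these few. Any claim that something is new, unique, unknown or untested is made for them only; others in the source may bear on it.

Measured so far in a functional assay on Bel-7402 cells (Homo sapiens) for cytotoxicity, read by MTT assay; on this read-out lower numbers stand for stronger inhibition and higher numbers for weaker inhibition:
- compound 1 `Cc1nc(Nc2ccc(Cl)cc2)sc1C(=O)/C=C/c1ccccc1` gives > 25000 nM
- compound 2 `Cc1nc(Nc2cccc(Cl)c2)sc1C(=O)/C=C/c1ccccc1` gives > 25000 nM
- compound 3 `Cc1cccc(Nc2nc(C)c(C(=O)/C=C/c3ccccc3Cl)s2)c1` gives > 25000 nM

All three values are limits of the assay rather than numbers, as the limit of > 25000 nM in this assay, at which 3 of the 3 values shown sit, states. Compound 2 therefore stands nowhere inside the series; it sits at the limit, and the two other values shown are limits too. Among the compounds with values here, the one step between compounds differing in a single place, from compound 1 to compound 2, is a step that the two limits leave unreadable from compound 1 to compound 2 and gives no size or direction for exchanging 4-chlorophenyl for 3-chlorophenyl on the aniline nitrogen.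

Compound 4 `Cc1nc(Nc2ccc(Cl)c(Cl)c2)sc1C(=O)/C=C/c1ccccc1` is not yet measured. Its difference from compound 2 is chloro in place of hydrogen on an aromatic carbon. Within the data shown here, no measured step bears on this change, and the only step available is unreadable, so nothing in the numbers points toward a stronger or weaker result for compound 4 in this assay. The expectation can rest only on the limit at which compound 2 sits.

The expected step from compound 2 to compound 4 is a step that the limit leaves unreadable from compound 2 to compound 4, which means no change read beyond the scatter. Compound 4 is accordingly estimated at 30000 nM, with a range from 8000 nM to 120000 nM, and most probably it will again be reported only as a limit.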

Compound 4, half-maximal inhibitory concentration: 21500 nM
Estimate against measurement, compound 4: 1.4-fold (0.14 log units) above, and the stated range covers the measured number.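

In this assay compound 4 is the only compound shown that returns a number, 21500 nM, so the 3,4-dichlorophenyl group on the aniline nitrogen is the first substitution in the series to come within the measurable range. The second chloro can now be placed against both single-chloro compounds, as an at least 1.1-fold lower number from compound 2 to compound 4 (0.06 log units; that floor lies within the scatter) and as an at least 1.1-fold lower number from compound 1 to compound 4 (0.06 log units; that floor lies within the scatter). Each of these steps gives a direction and a floor, not a size, so the true difference may be larger than the floor, and the steps among the remaining compounds still cannot be read: the limit of > 25000 nM in this assay, at which 3 of the 4 values shown sit.

The compounds shown leave open whether chlorine is needed at all at this position, since a methoxy, a trifluoromethyl or a dimethylamino group in place of the added chloro would separate the effect of this particular atom from that of any second group on the ring. Also open, from the compounds shown here alone, is whether the series can move well clear of the limit, and whether a change on the far phenyl ring or a longer chain in place of the methyl on the core would add to the step seen here.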